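A hydroxyphenyl swap on a shared core

The source may report more compounds than this note shows. Statements on the series, on what has been measured and on what is new or still open speak of the compounds shown alone.

Three compounds have numbers in a functional assay on MCF-A cells (Homo sapiens) for cytotoxicity; a lower number here means a stronger inhibitor of growth, a higher number a weaker inhibitor of growth. Compound 1 `COc1ccc(C2=C(c3ccc(SC)cc3)CC3CCCN3C2=O)cc1OC(=O)C1CCCN1C(=O)OC(C)(C)C` gives 4000 nM, compound 3 `COc1ccc(C2=C(c3ccc(SC)cc3)CC3CCCN3C2=O)cc1OC` gives 600 nM, and compound 2 `CSc1ccc(C2=C(c3ccc(F)c(F)c3)C(=O)N3CCCC3C2)cc1` gives 800 nM. Compound 2 therefore sits level with compound 3 within the scatter and well below compound 1, beyond the scatter. The unmeasured compound 4 `CSc1ccc(C2=C(c3ccc(O)cc3)C(=O)N3CCCC3C2)cc1` carries 4-hydroxyphenyl in place of 3,4-difluorophenyl on a double-bonded ring carbon. Among the compounds with values here, no two measured compounds differ in only one place, so the data offer no direct guide to this swap, and no change beyond the scatter is expected. The expected step is a 1.1-fold higher number from compound 2 to compound 4 (0.05 log units; within the scatter). Compound 4 is estimated at 900 nM, with an expected range from 250 nM to 3000 nM.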

Compound 4, concentration for 50% growth inhibition: > 100000 nM
Compound 4: only a limit was reported; the forecaster's own chance of this, stated with the estimate: 5%; at least 110-fold (2.04 log units) between middle value and limit.
By their numbers in this assay, from the lowest: compounds 3 and 2 (each within the scatter of the next); then compound 1. At a limit, above all of these: compound 4.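

Within the data shown here, replacing 3,4-difluorophenyl with 4-hydroxyphenyl gives an at least 120-fold higher number from compound 2 to compound 4 (2.09 log units; beyond the scatter) in this assay, the first comparison here in which only one place changes. It shows that growth inhibition depends strongly on which aromatic group sits on this double-bonded ring carbon. Compound 4 stands at a limit, not at an exact number: the limit of > 100000 nM in this assay, at which 1 of the 4 values shown sits.

The compounds shown cannot separate the loss of the two fluorines from the arrival of the hydroxyl. Plain phenyl or 4-fluorophenyl at this carbon would help tell these two changes apart.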